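This account rests on a few compounds, and the source may have more. Where it says the series, first, only, none or still open, it means among the compounds named here.

In an in vitro ADME assay on microsomes from liver (Homo sapiens) for metabolic stability, tested at 5 uM (a lower number here means that the compound disappears faster, a higher number that the compound lasts longer), compound 1 `CC(C)CCn1nc(-c2cccs2)c(O)c(C2=NS(=O)(=O)c3cc(O)ccc3N2)c1=O` gives 0.0933 h, and compound 2 `CC(C)CCn1nc(-c2cccs2)c(O)c(C2=NS(=O)(=O)c3cc(OC(C)C(N)=O)ccc3N2)c1=O` gives 0.217 h, the higher of the two numbers; the step of a 2.3-fold higher number from compound 1 to compound 2 (0.37 log units; beyond the scatter) separates them. Compound 3 `CCC(Oc1ccc2c(c1)S(=O)(=O)N=C(c1c(O)c(-c3cccs3)nn(CCC(C)C)c1=O)N2)C(N)=O` differs from compound 2 by methyl in place of hydrogen on a saturated chain carbon, two bonds along the chain from a carbonyl carbon and an oxygen on an aromatic ring. Within the data shown here, no measured step tests this change directly; the only step known here, a 2.3-fold higher number from compound 1 to compound 2 (0.37 log units; beyond the scatter), concerns a different addition and is itself modest. A step no larger than the usual scatter, in either direction, is therefore expected for compound 3 in this assay, a 1.2-fold higher number from compound 2 to compound 3 (0.06 log units; within the scatter). Compound 3 is estimated at 0.25 h, within a range from 0.11 h to 0.6 h.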

Compound 3, half-life: 0.35 h
Compound 3: middle estimate off by 1.4-fold (0.15 log units), on the low side; measured number inside the range.
By their numbers in this assay, from the lowest: compound 1; then compounds 2 and 3 (each within the scatter of the next).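

In this assay methyl in place of hydrogen on this saturated chain carbon gives a 1.6-fold higher number from compound 2 to compound 3 (0.21 log units; within the scatter), so the 1-carbamoylethoxy and 1-carbamoylpropoxy groups cannot be told apart here. Set against the hydrogen on the oxygen in compound 1, the 1-carbamoylpropyl group still gives a clear step, a 3.8-fold higher number from compound 1 to compound 3 (0.57 log units; beyond the scatter), as the 1-carbamoylethyl group did. Nothing available explains either step.

The compounds shown leave open how a longer chain on this carbon would behave. They also leave open what a carboxylic acid in place of the terminal amide would do to the half-life.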